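Trimming the chain from compound 3 to compound 4

This account rests on a few compounds, and the source may have more. Where it says the series, first, only, none or still open, it means among the compounds named here.

In a functional assay on HCT-116 cells (Homo sapiens) for cytotoxicity (on this read-out higher numbers stand for weaker inhibition and lower numbers for stronger inhibition), compound 1 `CCCCCCCCC[C@@H]1CC(=O)N[C@H](CC(C)C)C(=O)N[C@@H](CO)C(=O)N[C@@H]([C@@H](C)O)C(=O)N[C@H](CC(C)C)C(=O)N[C@@H]([C@@H](C)CC)C(=O)O1` gives 22000 nM, compound 2 `CC[C@H](C)[C@@H]1NC(=O)[C@@H](CC(C)C)NC(=O)[C@H]([C@@H](C)O)NC(=O)[C@H](CO)NC(=O)[C@@H](CC(C)C)NC(=O)C[C@@H](CCCCCCC(C)C)OC1=O` gives 50000 nM and compound 3 `CCCCCCCCCCC[C@@H]1CC(=O)N[C@H](CC(C)C)C(=O)N[C@@H](CO)C(=O)N[C@@H]([C@@H](C)O)C(=O)N[C@H](CC(C)C)C(=O)N[C@@H]([C@@H](C)CC)C(=O)O1` gives 18000 nM. Compound 3 stands level with compound 1, as a 1.2-fold lower number from compound 1 to compound 3 (0.09 log units; within the scatter) shows, and apart from compound 2, as a 2.8-fold lower number from compound 2 to compound 3 (0.44 log units; beyond the scatter) shows.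

Compound 4 `CCCCCCCCCC[C@@H]1CC(=O)N[C@H](CC(C)C)C(=O)N[C@@H](CO)C(=O)N[C@@H]([C@@H](C)O)C(=O)N[C@H](CC(C)C)C(=O)N[C@@H]([C@@H](C)CC)C(=O)O1` differs from compound 3 by a single change, hydrogen in place of methyl on a saturated chain carbon, ten or more bonds along the chain from a saturated ring carbon.

The closest measured precedent is a 1.2-fold lower number from compound 1 to compound 3 (0.09 log units; within the scatter), with ethyl in place of hydrogen on a saturated chain carbon, and it stays within the scatter. The two larger steps, a 2.3-fold higher number from compound 1 to compound 2 (0.36 log units; beyond the scatter) and a 2.8-fold lower number from compound 2 to compound 3 (0.44 log units; beyond the scatter), are modest, and both run through the isopropyl chain of compound 2. The change at hand involves no isopropyl group, so these two bear on it only weakly. No step beyond the scatter is therefore expected in this assay. The expected step is a 1.1-fold higher number from compound 3 to compound 4 (0.05 log units; within the scatter). The estimated value for compound 4 is 20000 nM, with an expected range of 12000 nM to 33000 nM.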

Compound 4, half-maximal inhibitory concentration: 32000 nM
The estimate for compound 4 lay 1.6-fold (0.20 log units) below the measured number, within the range that was stated.
By their numbers in this assay, from the lowest: compounds 3, 1, 4 and 2 (each within the scatter of the next, the first and the last beyond it).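

In this assay, hydrogen in place of methyl on a saturated chain carbon, ten or more bonds along the chain from a saturated ring carbon, gives a 1.8-fold higher number from compound 3 to compound 4 (0.25 log units; within the scatter) and methyl in place of hydrogen on a saturated chain carbon, nine bonds along the chain from a saturated ring carbon, gives a 1.5-fold higher number from compound 1 to compound 4 (0.16 log units; within the scatter) as well. Together with the earlier step between compound 1 and compound 3, these place all three unbranched chains within the scatter of one another. Replacing the isopropyl chain with an unbranched one gives a 1.6-fold lower number from compound 2 to compound 4 (0.19 log units; within the scatter) in turn. The isopropyl chain of compound 2 thus no longer stands apart from every unbranched chain, although its steps to compound 1 and compound 3 remain beyond the scatter. No measurement at hand accounts for these steps.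

A longer chain than that of compound 3, or a chain ending in a hydroxyl or an amine, lies outside the compounds shown. As far as these compounds go, whether any such change at this end of the chain would give a step clearly beyond the scatter in this assay remains open.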